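Moving the carboxyl group on the aryl ether end

The compounds below may be only part of what the source reports. "The series", "measured", "known", "first", "only" and "open" are said of these compounds alone.

Compound 2 `Cc1ccc(C(=O)O)cc1OCCCCOc1ccc(C(=O)CC2CCCC2)c(O)c1C` gives 26.9% in an assay on HEK293 cells for positive allosteric modulation of metabotropic glutamate receptor 3 (Rattus norvegicus), read by thallium flux, with a stated time of 2.5 min (a higher number here means a larger maximal response, a lower number a smaller maximal response), the lowest of the two numbers measured, with compound 1 `Cc1c(OCCCCOc2ccc(C(=O)O)cc2Cl)ccc(C(=O)CC2CCCC2)c1O` nearest at 27.4%; the step of a number 0.5 percentage points lower from compound 1 to compound 2 (within the scatter) lies within the scatter. Compound 3 `Cc1cc(C(=O)O)ccc1OCCCCOc1ccc(C(=O)CC2CCCC2)c(O)c1C` has not yet been measured. It differs from compound 2 by 4-carboxy-2-methylphenyl in place of 5-carboxy-2-methylphenyl on an oxygen on a saturated carbon. Among the compounds with values here, the only measured step, a number 0.5 percentage points lower from compound 1 to compound 2 (within the scatter), changed the aryl ether group without moving the maximal response beyond the scatter, so for compound 3 the expected step of a number 0.1 percentage points higher from compound 2 to compound 3 (within the scatter) is none beyond the scatter. Compound 3 is estimated at 27%, in the range 17% to 38%.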

Compound 3, largest response reached (reported as percent of maximum), in percent of the reference or control that the assay uses: 28.4%
Beside the measured number, compound 3's estimate is 1.4 percentage points below it, within the range that was stated.
By their numbers in this assay, from the lowest: compounds 2, 1 and 3 (each within the scatter of the next).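

In this assay, 4-carboxy-2-methylphenyl in place of 5-carboxy-2-methylphenyl gives a number 1.5 percentage points higher from compound 2 to compound 3 (within the scatter) and so does not separate the two carboxyl placements on this aryl ether. Methyl in place of chloro on an aromatic carbon, with the carboxyl placement held, gives a number 1 percentage points higher from compound 1 to compound 3 (within the scatter) and likewise separates nothing. No evidence is available on why the maximal response stays the same across these changes. The compounds shown leave open whether a tetrazole or a primary amide in place of the carboxylic acid, or a longer chain on the oxygen, would move the response beyond the scatter.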